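A Urea Aryl Swap Carried Over to a Second Core

The compounds below may be only part of what the source reports. "The series", "measured", "known", "first", "only" and "open" are said of these compounds alone.

Three ureas have been measured in a functional assay on MKN-45 cells (Homo sapiens) for cytotoxicity, read by MTT assay, with a stated time of 72 h (on this read-out higher numbers stand for weaker inhibition and lower numbers for stronger inhibition), and a fourth remains to be tested. Compound 1 `CN(C)CCCNc1nc(-c2ccc(NC(=O)Nc3ccc(Cl)cc3Cl)cc2)nc2c(Cl)c(Cl)sc12` gives 2560 nM in this assay. Compound 2 `Cc1ccc(NC(=O)Nc2ccc(-c3nc(NCCCN(C)C)c4sc(Cl)c(Cl)c4n3)cc2)cc1` keeps the core of compound 1; in this assay compound 2 gives 3700 nM. Compound 3 `CN(C)CCNc1nc(-c2ccc(NC(=O)Nc3ccc(Cl)cc3Cl)cc2)nc2ccsc12` gives 2360 nM in this assay. The difference between the core of compound 1 and the core of compound 3 is not broken down here.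

The change from compound 1 to compound 2 is 4-methylphenyl in place of 2,4-dichlorophenyl on an amide-type nitrogen. It made a 1.4-fold higher number from compound 1 to compound 2 (0.16 log units; within the scatter). The unmeasured compound 4 `Cc1ccc(NC(=O)Nc2ccc(-c3nc(NCCN(C)C)c4sccc4n3)cc2)cc1` stands to compound 3 as compound 2 stands to compound 1: the change is 4-methylphenyl in place of 2,4-dichlorophenyl on an amide-type nitrogen. The place is described in the same words for both pairs, an amide-type nitrogen whose other neighbours are a carbonyl carbon, so it is the same change applied on a different core. Among the four compounds it appears twice in all.

The expectation for compound 4 rests on that one measured step: because compound 1 and compound 2 are separated by a 1.4-fold higher number from compound 1 to compound 2 (0.16 log units; within the scatter), a step of similar size is estimated from compound 3, namely a 1.4-fold higher number from compound 3 to compound 4 (0.15 log units; within the scatter). Going by the values given here, on that basis compound 4 is expected to give about 3300 nM in this assay, with a range from 1500 nM to 7500 nM, the width reflecting that only one prior example of this change is available and that the two cores differ in a way not resolved here.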

Compound 4, half-maximal inhibitory concentration: 2380 nM
The estimate for compound 4 lay 1.4-fold (0.14 log units) above the measured number, and the stated range covers the measured number.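

In this assay, 4-methylphenyl in place of 2,4-dichlorophenyl on the amide-type nitrogen gave a 1.0-fold higher number from compound 3 to compound 4 (0.00 log units; within the scatter). Set beside the earlier step, the same change reads alike on the two cores: the same change on two cores in this assay, a 1.4-fold higher number (0.16 log units; within the scatter) from compound 1 to compound 2 and a 1.0-fold higher number (0.00 log units; within the scatter) from compound 3 to compound 4, 1.4-fold (0.16 log units) apart, within the scatter of two such steps. This shows that in these two pairs the swap stayed within the scatter on each core and that nothing separates how the two cores responded, but neither step stands clear of the scatter, so the result does not show a transferable effect of any size, and two pairs cannot establish a rule for the wider series.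

The compounds shown carry only 2,4-dichlorophenyl and 4-methylphenyl on that nitrogen, so it remains open whether an unsubstituted phenyl, a 4-methoxyphenyl or a cyclohexyl group there would read differently on either core. On these data alone, it also remains open whether a morpholine in place of the dimethylamino group would leave the swap just as flat, and how much of the difference between the cores of compound 1 and compound 3 matters at all in this cell assay.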